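A few compounds are considered here, and "the series" means these few. Any claim that something is new, unique, unknown or untested is made for them only; others in the source may bear on it.

Measured compounds:
Compound 1 `CC1=C(C(O)Cc2ccc(C(C)(C)C)cc2)C(C)(C)CCC1`. In an ADME assay on HepG2 cells (Homo sapiens) for cytotoxicity, read by MTT assay, with a stated time of 24 h (a higher number here means that more compound is tolerated, a lower number that less compound is tolerated), compound 1 gives > 100000 nM, which is a limit of the assay and not a number.
Compound 2 `COc1ccc(CC(O)C2=C(C)CCCC2(C)C)cc1`. In this assay compound 2 gives > 100000 nM, again a limit.
Compound 3 `CC1=C(C(O)Cc2ccccc2)C(C)(C)CCC1`. In this assay compound 3 gives > 100000 nM, also a limit.

Compound 3 therefore stands where every measured compound of the series stands: the limit of > 100000 nM in this assay, at which 3 of the 3 values shown sit. No order among compounds 1, 2 and 3 can be read from these values.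

Compound 4 `CC1=C(C(O)Cc2ccc(C(C)C)cc2)C(C)(C)CCC1` differs from compound 3 by isopropyl in place of hydrogen on an aromatic carbon. The measured steps that bear on a group at this aromatic carbon are a step that the two limits leave unreadable from compound 1 to compound 2, a step that the two limits leave unreadable from compound 1 to compound 3 and a step that the two limits leave unreadable from compound 2 to compound 3; each runs between two limits, so none has a readable size. Compound 1 carries tert-butyl at the same place and sits at the limit, and compound 3 carries hydrogen there and sits at the limit, so nothing in the series marks this position as one where a change shows up.

No step beyond the scatter is expected, and the estimated step that the limit leaves unreadable from compound 3 to compound 4 is expected to be nil within scatter. Compound 4 is expected to return the same limit and is estimated at 150000 nM, with a range from 50000 nM to 500000 nM.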

Compound 4, half-maximal cytotoxic concentration: > 100000 nM
Compound 4 gave a limit, no number; the forecaster's own chance of this, stated with the estimate: 85%; the middle value is on the limit's open side.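

In this assay no new step can be read: the steps joining compound 4 to compound 1, compound 2 and compound 3 all run between limits, so none has a size. The series now stands at one place: the limit of > 100000 nM in this assay, at which 4 of the 4 values shown sit.

The compounds shown leave open what the half-maximal cytotoxic concentration of any of the four is, and whether the group on the aromatic carbon bears on it at all.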